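The compounds below may be only part of what the source reports. "The series", "measured", "known", "first", "only" and "open" are said of these compounds alone.

Measured compounds:
- Compound 1, `Cc1ccc(-c2nc3c(=O)n(C)c(=O)n(C)c3[nH]2)cc1`: 0.8 nM
- Compound 2, `CCOc1ccc(-c2nc3c(=O)n(C)c(=O)n(C)c3[nH]2)cc1`: 2 nM

Both compounds were tested in an assay for binding affinity to adenosine receptor A1 (Bos taurus); on this read-out higher numbers stand for weaker inhibition and lower numbers for stronger inhibition. Compound 1 gives 0.8 nM, and compound 2 gives 2 nM. Within the data shown here, of these two numbers, compound 2 has the higher one, so it is the weaker of the pair; the only comparison available is a 2.5-fold higher number from compound 1 to compound 2 (0.40 log units; beyond the scatter), a modest but real difference.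

Compound 3, `Cn1c(=O)c2nc(-c3ccc(Br)cc3)[nH]c2n(C)c1=O`, has not yet been measured. Its change from compound 2 is bromo in place of ethoxy on an aromatic carbon, on an aromatic carbon of a six-membered aromatic ring of carbon only, para to a large group. Among the measured compounds shown here, no measured step covers bromo directly. For the measured compounds named here, the one step that bears on it, a 2.5-fold higher number from compound 1 to compound 2 (0.40 log units; beyond the scatter), shows that a small methyl at this position gave a lower number than ethoxy. Bromo is likewise a single small atom rather than a chain with an oxygen, so a step back toward the lower number is expected, though it may stay within the scatter.

Compound 3 is therefore estimated at 1.2 nM, with a likely range of 0.4 nM to 4 nM. The expected step is a 1.7-fold lower number from compound 2 to compound 3 (0.22 log units; within the scatter).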

Compound 3, half-maximal inhibitory concentration: 0.75 nM
Compound 3: the middle estimate sits 1.6-fold (0.20 log units) above what was measured, within the range that was stated.
By their numbers in this assay, from the lowest: compounds 3 and 1 (each within the scatter of the next); then compound 2.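

In this assay, putting bromo in place of ethoxy gives a 2.7-fold lower number from compound 2 to compound 3 (0.43 log units; beyond the scatter), so the higher number of compound 2 now stands against two other groups at this position rather than against methyl alone. Bromo and methyl cannot be told apart, as a 1.1-fold lower number from compound 1 to compound 3 (0.03 log units; within the scatter) shows, which means that of the three groups on this aromatic carbon, para to a large group, only ethoxy stands apart, while two quite different groups land at the same level. Nothing measured here explains why ethoxy differs from the other two or why bromo and methyl match.

The compounds shown leave open how an amine, a carboxylic acid or a longer chain such as butoxy would read at this position, and whether the number would keep rising as the chain grows beyond ethoxy. They also leave open whether other single atoms, such as fluoro or chloro, would join bromo and methyl at the same level, or whether that match is limited to these two groups.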